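A few compounds are considered here, and "the series" means these few. Any claim that something is new, unique, unknown or untested is made for them only; others in the source may bear on it.

Compound 1 `Cn1c(Cc2nn(C)c(=O)c3ccccc23)nnc1SCCCCCCCC(=O)Nc1ccc(Cl)cc1Cl` gives in an assay on 32D cells for inhibition of interleukin-15 (Mus musculus), read by resazurin assay, with stated times of 30 min and 2.5 days, in the presence of a further agent that is not named here (a higher number here means a weaker inhibitor, a lower number a stronger inhibitor), a value of 2200 nM. For the measured compounds named here, compound 2 `Cn1c(Cc2nn(CCCO[Si](C)(C)C(C)(C)C)c(=O)c3ccccc23)nnc1SCCCCCCCC(=O)Nc1ccc(Cl)cc1Cl` differs from it only at the saturated chain carbon bound to an aromatic nitrogen, and the step of an at least 13-fold higher number from compound 1 to compound 2 (1.13 log units; beyond the scatter) is the one measured change. In this assay compound 2 reaches only a limit, > 30000 nM. As far as these compounds go, that compound 2 sits at the limit of > 30000 nM in this assay, at which 1 of the 2 values shown sits, means its true value is unknown beyond that bound, so the step from compound 1 is itself only a lower bound.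

Compound 3 `CN(C)CCCn1nc(Cc2nnc(SCCCCCCCC(=O)Nc3ccc(Cl)cc3Cl)n2C)c2ccccc2c1=O` takes the next step from compound 2: a group of 3 heavy atoms (2 carbon, 1 nitrogen; no ring) in place of a group of 8 heavy atoms (6 carbon, 1 oxygen, 1 silicon; no ring), on a saturated chain carbon, three bonds along the chain from an aromatic nitrogen. The large loss seen from compound 1 to compound 2 bears on this change, since compound 3 removes most of what compound 2 had added while keeping a chain on that aromatic nitrogen. Compound 3 is therefore expected to move back toward compound 1, by an estimated at least 3.7-fold lower number from compound 2 to compound 3 (0.57 log units; beyond the scatter), though not fully. The estimate for compound 3 in this assay is 8000 nM, with a range from 1500 nM to 40000 nM.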

Compound 3, half-maximal inhibitory concentration: 2300 nM
Beside the measured number, compound 3's estimate is 3.5-fold (0.54 log units) above it, and the stated range covers the measured number.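

Exchanging the end group of the chain for dimethylamino gives an at least 13-fold lower number from compound 2 to compound 3 (1.11 log units; beyond the scatter) in this assay, so the presence of a chain on that aromatic nitrogen does not by itself carry the loss seen with compound 2. The step of a 1.0-fold higher number from compound 1 to compound 3 (0.02 log units; within the scatter) shows that this chain ending in dimethylamino can stand on the shared core with no change beyond the scatter. The recovery from compound 2 can be read only as a bound because that compound's value is a limit: the limit of > 30000 nM in this assay, at which 1 of the 3 values shown sits.

As far as these compounds go, whether a primary amine, a carboxylic acid or a longer chain would fare like dimethylamino at this place stays open. The compounds shown also cannot tell which part of the group leaving compound 2 carries the loss, and a hydroxyl at the same chain end would bear on that.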